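A few compounds are considered here, and "the series" means these few. Any claim that something is new, unique, unknown or untested is made for them only; others in the source may bear on it.

Compound 1 `COc1cc2oc(-c3cccc(NC(=O)c4ccc(Cl)cc4)c3)cc(=O)c2c(OC)c1OC` holds the lower of the two numbers shown: in a functional assay on HepG2 cells (Homo sapiens) for inhibition, read by MTT assay (a lower number here means a stronger inhibitor of growth, a higher number a weaker inhibitor of growth), compound 1 gives 21300 nM. For the measured compounds named here, its only measured neighbour, compound 2 `COc1cc2oc(-c3cccc(NC(=O)c4ccc(F)cc4)c3)cc(=O)c2c(OC)c1OC`, gives 47200 nM in this assay, and between them stands the step of a 2.2-fold higher number from compound 1 to compound 2 (0.35 log units; beyond the scatter), which came from fluoro in place of chloro on an aromatic carbon. Compound 3 `COc1ccc(C(=O)Nc2cccc(-c3cc(=O)c4c(OC)c(OC)c(OC)cc4o3)c2)cc1` differs from compound 1 by methoxy in place of chloro on an aromatic carbon. Going by the values given here, no measured pair shows methoxy entering for chloro, so the sole guide is that one halogen exchange at the same place, which moved the number only modestly and upward. A step of similar size, most likely toward a higher number but possibly none beyond the scatter, is therefore expected in this assay. Compound 3 is estimated to give 32000 nM, with a likely range from 13000 nM to 80000 nM. This estimate amounts to an expected step of a 1.5-fold higher number from compound 1 to compound 3 (0.18 log units; within the scatter).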

Compound 3, concentration for 50% growth inhibition: 22200 nM
Compound 3: middle estimate off by 1.4-fold (0.16 log units), on the high side, within the range that was stated.
By their numbers in this assay, from the lowest: compounds 1 and 3 (each within the scatter of the next); then compound 2.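

In this assay, methoxy in place of chloro on an aromatic carbon para to a large group gives a 1.0-fold higher number from compound 1 to compound 3 (0.02 log units; within the scatter) and so leaves the two groups indistinguishable at this position, although methoxy brings a hydrogen-bond acceptor and chloro none. Methoxy in place of fluoro at the same place gives a 2.1-fold lower number from compound 2 to compound 3 (0.33 log units; beyond the scatter) and thus a modest step of nearly the same size as the one between chloro and fluoro, so among these three compounds, compound 2 with its fluoro is the one set apart. No measurement offered here accounts for this difference.

From the compounds shown here alone, whether an amine, a carboxylic acid or a longer chain such as butoxy at this position would keep the number level with compound 1 or shift it remains open. Also open, going by these compounds, is how chloro, fluoro and methoxy would behave at other carbons of the same ring.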